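The compounds below may be only part of what the source reports. "The series", "measured", "known", "first", "only" and "open" are said of these compounds alone.

Measured compounds:
compound 1 `Cc1ccc(S(=O)(=O)Oc2ccc3c(c2C)[C@H](Cn2cc(-c4ccc(C(F)(F)F)cc4)nn2)[C@@]24CC(=O)[C@@](C)(CC[C@@H]32)C4)cc1` — > 20000 nM
compound 2 `Cc1ccc(S(=O)(=O)Oc2ccc3c(c2C)[C@H](Cn2cc(-c4ccc(Br)cc4)nn2)[C@@]24CC(=O)[C@@](C)(CC[C@@H]32)C4)cc1` — > 20000 nM
compound 3 `Cc1ccc(S(=O)(=O)Oc2ccc3c(c2C)[C@H](Cn2cc(-c4ccc(F)cc4)nn2)[C@@]24CC(=O)[C@@](C)(CC[C@@H]32)C4)cc1` — > 20000 nM

In a functional assay on MCF7 cells (Homo sapiens) for cytotoxicity, read by MTT assay, with a stated time of 4 days (on this read-out higher numbers stand for weaker inhibition and lower numbers for stronger inhibition), compound 1 gives only a limit, > 20000 nM, and not a number. In this assay compound 2 likewise gives a limit, > 20000 nM. Compound 3 also gives a limit, > 20000 nM. All three values sit at the limit of > 20000 nM in this assay, at which 3 of the 3 values shown sit, so compound 1 stands on the same limit as its two neighbours, and the measured steps from compound 1 to compound 2 a step that the two limits leave unreadable from compound 1 to compound 2, from compound 1 to compound 3 a step that the two limits leave unreadable from compound 1 to compound 3 and from compound 2 to compound 3 a step that the two limits leave unreadable from compound 2 to compound 3 have no readable size.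

Compound 4 `Cc1c(O)ccc2c1[C@H](Cn1cc(-c3ccc(C(F)(F)F)cc3)nn1)[C@@]13CC(=O)[C@@](C)(CC[C@@H]21)C3` has not yet been measured in this assay. It differs from compound 1 by hydrogen in place of (4-methylphenyl)sulfonyl on an oxygen on an aromatic ring. Within the data shown here, none of the measured steps touches this position: those steps exchange substituents on the aromatic carbon of the other ring, and each of them runs between two limits. Among the measured compounds shown here, no measured step therefore bears on the change from compound 1 to compound 4, and its direction in this assay is open.

With nothing to read from, compound 4 is estimated at 15000 nM, within 3000 nM to 60000 nM. The step from compound 1 to compound 4 that this estimate means is expected to be an at least 1.3-fold lower number from compound 1 to compound 4 (0.12 log units; that floor lies within the scatter).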

Compound 4, half-maximal inhibitory concentration: > 20000 nM
Compound 4: a limit, no number; the forecaster's own chance of this, stated with the estimate: 55%; middle value at least 1.3-fold (0.12 log units) away from the limit.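

In this assay compound 4 gives only a limit, > 20000 nM, as compound 1 does, so no size can be read for the change between compound 1 and compound 4: the limit of > 20000 nM in this assay, at which 4 of the 4 values shown sit.

None of the four compounds gives a number, so the compounds shown leave open the size and direction of hydrogen in place of (4-methylphenyl)sulfonyl and of the exchanges on the aromatic carbon.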